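Side-chain amine swaps in the alkynyl thio series

The source may report more compounds than this note shows. Statements on the series, on what has been measured and on what is new or still open speak of the compounds shown alone.

Values in a functional assay on SNB-19 cells (Homo sapiens) for antiproliferative activity, read by WST assay, with a stated time of 72 h; a lower number here means a stronger inhibitor, a higher number a weaker inhibitor:
- compound 1 `CCN(CC)CC#CCSc1nc2c(c(=O)[nH]c(=O)n2C)n1C`: 1480 nM
- compound 2 `Cn1c(SCC#CCN2CCCC2)nc2c1c(=O)[nH]c(=O)n2C`: 177000 nM

Compound 2 holds the higher of the two numbers. Compound 3 `Cn1c(SCC#CCN2CCCCC2)nc2c1c(=O)[nH]c(=O)n2C` carries piperidin-1-yl in place of pyrrolidin-1-yl on a saturated chain carbon bound to a triple-bonded carbon. Going by the values given here, the one measured step at this place is a 120-fold higher number from compound 1 to compound 2 (2.08 log units; beyond the scatter), which is large, so a sizeable move towards a lower number is expected in this assay, though a single step sets no trend. The expected change is an 8.9-fold lower number from compound 2 to compound 3 (0.95 log units; beyond the scatter). Compound 3 is estimated at 20000 nM (range 1500 nM to 180000 nM).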

Compound 3, half-maximal inhibitory concentration: 166000 nM
Compound 3: middle estimate off by 8.3-fold (0.92 log units), on the low side, within the range that was stated.
By their numbers in this assay, from the lowest: compound 1; then compounds 3 and 2 (each within the scatter of the next).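

In this assay, the swap from a five-membered to a six-membered ring on the saturated chain carbon gives no readable difference (a 1.1-fold lower number from compound 2 to compound 3 (0.03 log units; within the scatter)). The large gap to diethylamino returns with the second ring (a 110-fold higher number from compound 1 to compound 3 (2.05 log units; beyond the scatter)), so among these compounds it is not peculiar to pyrrolidin-1-yl.

Still open, from the compounds shown here alone, is whether other amines, such as dimethylamino, dipropylamino or morpholin-4-yl, stay near compound 1 or near the two ring compounds. A longer chain carrying diethylamino is equally unresolved. No evidence on hand bears on this result.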